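A few compounds are considered here, and "the series" means these few. Any claim that something is new, unique, unknown or untested is made for them only; others in the source may bear on it.

Measured so far in an assay on brain for displacement of a labelled ligand from D(3) dopamine receptor (Rattus norvegicus); on this read-out lower numbers stand for stronger inhibition and higher numbers for weaker inhibition:
compound 1 `CCCN(CC[C@H]1CC[C@H](NC(=O)/C=C/c2cccc(F)c2)CC1)[C@H]1CCc2nc(N)sc2C1`, 9.9 nM
compound 2 `CCCN(CC[C@H]1CC[C@H](NC(=O)/C=C/c2ccccc2Cl)CC1)[C@H]1CCc2nc(N)sc2C1`, 1.2 nM
compound 3 `CCCN(CC[C@H]1CC[C@H](NC(=O)/C=C/c2cccc(OC)c2)CC1)[C@H]1CCc2nc(N)sc2C1`, 9.3 nM

Compound 3 stands second highest of the three numbers. Its nearest neighbour is compound 1, and the gap there is a 1.1-fold lower number from compound 1 to compound 3 (0.03 log units; within the scatter), so no order between compound 1 and compound 3 can be read. Compound 2 sits apart from both: a 7.8-fold higher number from compound 2 to compound 3 (0.89 log units; beyond the scatter) and an 8.3-fold lower number from compound 1 to compound 2 (0.92 log units; beyond the scatter), each beyond the scatter.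

Compound 4 `CCCN(CC[C@H]1CC[C@H](NC(=O)c2cccc3cnccc23)CC1)[C@H]1CCc2nc(N)sc2C1` differs from compound 3 in isoquinolin-5-yl in place of 2-(3-methoxyphenyl)ethenyl on a carbonyl carbon. Among the compounds with values here, none of the measured steps covers a change of this kind. All three measured compounds keep the ethenyl chain and the amide, and vary only the substituted phenyl at its end; the step of an 8.3-fold lower number from compound 1 to compound 2 (0.92 log units; beyond the scatter) shows how far that aryl part alone can move the read-out. The change to compound 4 removes the ethenyl chain and brings in a bicyclic aryl directly on the carbonyl carbon, which goes beyond anything measured, so neither direction nor size can be read from the series, and the range has to be set wide.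

Compound 4 is expected to give about 15 nM, with a range from 3 nM to 70 nM. The expected step is a 1.6-fold higher number from compound 3 to compound 4 (0.21 log units; within the scatter), which is not beyond the scatter.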

Compound 4, inhibition constant: 5.9 nM
Estimate against measurement, compound 4: 2.5-fold (0.41 log units) above, within the range that was stated.
By their numbers in this assay, from the lowest: compound 2; then compounds 4, 3 and 1 (each within the scatter of the next).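

In this assay, isoquinolin-5-yl on the carbonyl carbon stands level with the 2-(3-methoxyphenyl)ethenyl and 2-(3-fluorophenyl)ethenyl groups, with a 1.6-fold lower number from compound 3 to compound 4 (0.20 log units; within the scatter) and a 1.7-fold lower number from compound 1 to compound 4 (0.22 log units; within the scatter) both inside the scatter, so among these compounds a value in this range does not depend on keeping an ethenyl chain on the carbonyl carbon. Compound 2 goes against any reading that the two kinds of group are interchangeable, since a 4.9-fold higher number from compound 2 to compound 4 (0.69 log units; beyond the scatter) lies beyond the scatter and compound 2 keeps the lowest number of the four, which shows that the 2-(2-chlorophenyl)ethenyl group is not matched by isoquinolin-5-yl. No supporting data bear on why these values fall as they do.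

The change removes the ethenyl chain and brings in the bicyclic aryl in a single step, so the share of each stays unresolved; a plain phenyl or a 2-chlorophenyl directly on the carbonyl carbon, or isoquinolin-5-yl carried on an ethenyl chain, would separate the two. As far as these compounds go, whether the ring nitrogen of isoquinolin-5-yl matters also stays open, and naphthalen-1-yl, with carbon in its place, would address that.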